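A few compounds are considered here, and "the series" means these few. Any claim that something is new, unique, unknown or untested is made for them only; others in the source may bear on it.

Compound 1 `Cc1nc(-c2ccccc2)sc1CN1C(=O)N(C)c2ccc(-c3c(C)noc3C)cc2C1c1ccccc1` gives 4.9% in an ADME assay on MCF-10A cells (Homo sapiens) for inhibition, read by MTT assay, with a stated time of 48 h, tested at 2 uM (on this read-out higher numbers stand for more inhibition at the one concentration tested (going by the name of the read-out) and lower numbers for less inhibition), and compound 2 `Cc1nc(-c2ccc(F)cc2)sc1CN1C(=O)N(C)c2ccc(-c3c(C)noc3C)cc2C1c1ccccc1` gives 6.5% in this assay; the two sit within the scatter of each other, so compound 1 stands alongside compound 2 rather than apart from it. Compound 3 `Cc1noc(C)c1-c1ccc2c(c1)C(c1ccccc1)N(Cc1nc(-c3ccc(F)cc3)cs1)C(=O)N2C` differs from compound 1 by 4-(4-fluorophenyl)-1,3-thiazol-2-yl in place of 4-methyl-2-phenyl-1,3-thiazol-5-yl on a saturated chain carbon bound to an amide-type nitrogen in a ring. For the measured compounds named here, the only measured step, a number 1.6 percentage points higher from compound 1 to compound 2 (within the scatter), adds a fluoro and stays within the scatter, but it does not test the rearranged thiazole that enters here, so the expected step is small with no clear direction. Compound 3 is therefore expected at 6%, between 0% and 16%, an expected step of a number 1.1 percentage points higher from compound 1 to compound 3 (within the scatter).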

Compound 3, a percentage reported as inhibition, at one concentration (the size of the read-out at that concentration, not a potency): 8.5%
The estimate for compound 3 lay 2.5 percentage points below the measured number, and the stated range covers the measured number.
By their numbers in this assay, from the lowest: compounds 1, 2 and 3 (each within the scatter of the next).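

Replacing 4-methyl-2-phenyl-1,3-thiazol-5-yl with 4-(4-fluorophenyl)-1,3-thiazol-2-yl gives a number 3.6 percentage points higher from compound 1 to compound 3 (within the scatter) in this assay. The earlier step altered only one hydrogen, whereas this one replaces the whole group on a saturated chain carbon bound to an amide-type nitrogen in a ring, and the change in the read-out still stays within the scatter. Nothing measured here offers a reason for this result. Both groups contain a thiazole and a six-membered aromatic ring of carbon only. Going by these compounds, how a group lacking these rings, such as an amine or a carboxylic acid, would behave at this place remains open.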